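The compounds below may be only part of what the source reports. "The series", "measured", "known", "first", "only" and "open" are said of these compounds alone.

The series shares the core shown in compound 1 `O=C(NC1CCCCC1)c1cc2ccc(OCc3ccccc3)cc2oc1=O`; in an in vitro assay on BTI-TN-5B1-4 cells for inhibition of Amine oxidase [flavin-containing] B (Homo sapiens), read by fluorescence (on this read-out higher numbers stand for weaker inhibition and lower numbers for stronger inhibition), compound 1 gives 64500 nM. For the measured compounds named here, compound 2 `COc1ccc(NC(=O)c2cc3ccc(OCc4ccccc4)cc3oc2=O)cc1OC` carries a 3,4-dimethoxyphenyl on the amide nitrogen, and in this assay compound 2 gives 4390 nM, the lowest of the two numbers so far; the only recorded step is a 15-fold lower number from compound 1 to compound 2 (1.17 log units; beyond the scatter). Compound 3 `COc1ccc(NC(=O)c2cc3ccc(OCc4ccc(F)cc4)cc3oc2=O)cc1OC` differs from compound 2 by fluoro in place of hydrogen on an aromatic carbon. Going by the values given here, the one measured step concerns the amide substituent, not the benzyloxy ring, so no measured step bears on this change; the expectation rests on the amide part of compound 3 being held unchanged from compound 2 with its 4390 nM. For compound 3 the step of a 1.1-fold lower number from compound 2 to compound 3 (0.04 log units; within the scatter) is expected to be none beyond the scatter. Compound 3 is estimated at 4000 nM in this assay, with a range from 1500 nM to 12000 nM.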

Compound 3, half-maximal inhibitory concentration: 2870 nM
Compound 3: the middle estimate sits 1.4-fold (0.14 log units) above what was measured; low and high end bracket the measured number.
By their numbers in this assay, from the lowest: compounds 3 and 2 (each within the scatter of the next); then compound 1.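

In this assay the fluoro change on the benzyloxy ring, para to a large group, gives a 1.5-fold lower number from compound 2 to compound 3 (0.18 log units; within the scatter) and so does not separate compound 3 from compound 2. This position therefore tolerates a single fluorine with the 3,4-dimethoxyphenyl amide held constant. For the compounds shown here, the amide change gives a 15-fold lower number from compound 1 to compound 2 (1.17 log units; beyond the scatter) and remains the only step beyond the scatter, while no available evidence bears on the result at the benzyloxy ring.

On these data alone, whether chloro, methoxy, trifluoromethyl or a carboxylic acid at this place would move the number beyond the scatter remains open. Also open, as far as these compounds go, is whether the fluoro change would read the same with cyclohexyl on the amide nitrogen, as in compound 1.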